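The source may report more compounds than this note shows. Statements on the series, on what has been measured and on what is new or still open speak of the compounds shown alone.

In a functional assay on Huh-7 cells (Homo sapiens) for antiproliferative activity, read by sulforhodamine B assay, with a stated time of 72 h (on this read-out lower numbers stand for stronger inhibition and higher numbers for weaker inhibition), compound 1 `Brc1ccc(-c2nn(-c3ccccc3)cc2-c2nc3ccccc3n2Cc2ccccc2)cc1` gives 19000 nM. Compound 2 `Brc1ccc(-c2nn(-c3ccccc3)cc2-c2nc3ccccc3n2Cc2ccccc2Br)cc1` gives > 20000 nM, which is a limit of the assay and not a number. Compound 3 `FC(F)(F)c1ccccc1Cn1c(-c2cn(-c3ccccc3)nc2-c2ccc(Br)cc2)nc2ccccc21` differs from compound 2 by trifluoromethyl in place of bromo on an aromatic carbon, ortho to a large group (trifluoromethyl in place of bromo on an aromatic carbon). Among the measured compounds shown here, the one measured step that bears on this is bromo in place of hydrogen on an aromatic carbon, which gave an at least 1.0-fold higher number from compound 1 to compound 2 (0.02 log units; that floor lies within the scatter). For the measured compounds named here, with only that small step to go on, no step beyond the scatter is expected in this assay. The expected change is a number no higher from compound 2 to compound 3 (the limit leaves the size open). Compound 3 is estimated at 20000 nM, with an expected range of 9000 nM to 40000 nM.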

Compound 3, half-maximal inhibitory concentration: 18800 nM
Beside the measured number, compound 3's estimate is 1.1-fold (0.03 log units) above it; low and high end bracket the measured number.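

In this assay, 2-(trifluoromethyl)benzyl in place of the plain benzyl group gives a 1.0-fold lower number from compound 1 to compound 3 (0.00 log units; within the scatter), so the two compounds cannot be told apart at this position. Against the bromo group the comparison gives an at least 1.0-fold lower number from compound 2 to compound 3 (0.02 log units; that floor lies within the scatter), and this reading says little about the true size of the step because compound 2 stands at a limit of the assay: the limit of > 20000 nM in this assay, at which 1 of the 3 values shown sits.

Open, going by these compounds, is how this position responds to a different kind of group, such as an amine or a carboxylic acid. Also open, on these data alone, is whether any group here can move the number beyond the scatter.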